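Swapping cyclopentyl for an aryl group on a shared core

This account rests on a few compounds, and the source may have more. Where it says the series, first, only, none or still open, it means among the compounds named here.

Measured compounds:
- Compound 1, `O=C1C(NC2CCCC2)=CC(=O)c2c1nc1n2[C@H]2OC[C@@H](O)[C@H]2OC1`: in a functional assay on ECa-109 cells for inhibition, with ECa-109 cell line (Homo sapiens) as the target, read by sulforhodamine B assay (on this read-out higher numbers stand for weaker inhibition and lower numbers for stronger inhibition), compound 1 gives > 16000 nM, which is a limit of the assay and not a number.
- Compound 2, `O=C1C=C(NC2CCCC2)C(=O)c2c1nc1n2[C@H]2OC[C@@H](O)[C@H]2OC1`: compound 2 gives > 16000 nM, likewise a limit of the assay.
- Compound 3, `O=C1C=C(Nc2ccc(I)cc2)C(=O)c2c1nc1n2[C@H]2OC[C@@H](O)[C@H]2OC1`: compound 3 gives 2300 nM.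

Compound 1 therefore stands only at a limit, and it shares that position with one other compound, as the limit of > 16000 nM in this assay, at which 2 of the 3 values shown sit, shows. Compound 4, `CCOc1ccccc1NC1=CC(=O)c2c(nc3n2[C@H]2OC[C@@H](O)[C@H]2OC3)C1=O`, has not yet been measured. It differs from compound 1 in one place: 2-ethoxyphenyl in place of cyclopentyl on an amine nitrogen.

Among the measured compounds shown here, the one measured step that resembles this change is the one between compound 2 and compound 3, where an aryl group also replaced cyclopentyl on the amine nitrogen: an at least 6.9-fold lower number from compound 2 to compound 3 (0.84 log units; beyond the scatter). That step started from a limit, so its true size may be larger than the figure shows. On this basis a step in the same direction, towards stronger inhibition, is expected for compound 4, roughly an at least 5.3-fold lower number from compound 1 to compound 4 (0.72 log units; beyond the scatter). For the measured compounds named here, compound 4 is thus estimated at 3000 nM, with a range from 800 nM to 12000 nM; only a single comparable step supports this, so the range is wide.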

Compound 4, half-maximal inhibitory concentration: 4320 nM
Estimate against measurement, compound 4: 1.4-fold (0.16 log units) below, and the stated range covers the measured number.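

In this assay, 2-ethoxyphenyl in place of cyclopentyl on the amine nitrogen gives an at least 3.7-fold lower number from compound 1 to compound 4 (0.56 log units; beyond the scatter). Until now, the only sign that an aryl group could bring measurable inhibition came from the step starting at compound 2, and compound 1 is an isomer of compound 2, so the same kind of swap now lowers the number in both arrangements of the shared core. The full size of the new step cannot be read, because compound 1 stands at a limit and not at a number: the limit of > 16000 nM in this assay, at which 2 of the 4 values shown sit.

The compounds shown leave open how much of the gain in compound 4 comes from the aromatic ring and how much from the ethoxy group attached to it; a plain phenyl group on the core of compound 1 would separate the two. They also leave open whether other groups on this amine nitrogen, such as a benzyl group or a 4-methoxyphenyl group, would lower the number further or raise it again.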